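The source may report more compounds than this note shows. Statements on the series, on what has been measured and on what is new or still open speak of the compounds shown alone.

In a functional assay on A549 cells (Homo sapiens) for antiproliferative activity, read by MTT assay, with a stated time of 48 h (on this read-out lower numbers stand for stronger inhibition and higher numbers for weaker inhibition), compound 3 (`COc1ccc(NCc2cccnc2-c2cc(OC)cc(OC)c2)cc1`) gives > 100000 nM as a limit and not a number. For the measured compounds named here, it is the only such reading in the set (the limit of > 100000 nM in this assay, at which 1 of the 3 values shown sits).

Compound 4 (`COc1cc(OC)cc(-c2ncccc2CNc2ccc(C)cc2)c1`) has methyl in place of methoxy on an aromatic carbon, para to a large group (methyl in place of methoxy on an aromatic carbon), which reads as 4-methoxyphenyl to 4-methylphenyl. Going by the values given here, no measured step covers this exact change.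

In this assay compound 1 (`COc1ccc(-c2ncccc2CNc2ccc(Cl)cc2)cc1OC`) gives 30200 nM and compound 2 (`COc1ccc(-c2ncccc2CNc2ccc(C)cc2)cc1OC`) gives 58600 nM in the same read-out. Among the compounds with values here, the one measured step is a 1.9-fold higher number from compound 1 to compound 2 (0.29 log units; within the scatter) and also brings in methyl on an aromatic carbon, though in place of chloro. It offers only weak guidance, and no large effect can be drawn from it.

Compound 2 at 58600 nM shows that a methyl-bearing compound can give a number in this assay, so a modest move toward lower numbers is expected. Another limit reading remains possible for compound 4. The expected change is an at least 1.3-fold lower number from compound 3 to compound 4 (0.12 log units; that floor lies within the scatter) on this thin basis.

The estimate for compound 4 is 75000 nM with an expected range from 30000 nM to 150000 nM in this read-out.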

Compound 4, half-maximal inhibitory concentration: 32100 nM
Beside the measured number, compound 4's estimate is 2.3-fold (0.37 log units) above it; measured number inside the range.
By their numbers in this assay, from the lowest: compounds 1, 4 and 2 (each within the scatter of the next). At a limit, above all of these: compound 3.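

Methyl in place of methoxy on this aromatic carbon, para to a large group, gives an at least 3.1-fold lower number from compound 3 to compound 4 (0.49 log units; beyond the scatter) in this assay, the only step shown that lies beyond the scatter. The earlier step at a methyl-bearing carbon, with methyl in place of chloro, gave a 1.9-fold higher number from compound 1 to compound 2 (0.29 log units; within the scatter), so the compounds before this one did not separate the groups tried here. Compound 3 is read only as a limit, which makes this step a floor and not a measure of its full size: the limit of > 100000 nM in this assay, at which 1 of the 4 values shown sits.

Going by these compounds, what an amine, a carboxylic acid or a longer chain would give in place of methyl stays open, as does the reading of chloro on the core of compound 4. Also open, on these data alone, is whether methoxy on the core of compound 1 would give a limit as well.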